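A few compounds are considered here, and "the series" means these few. Any claim that something is new, unique, unknown or untested is made for them only; others in the source may bear on it.

Measured compounds in an assay on isolated protein for inhibition of Indoleamine 2,3-dioxygenase 1 (Homo sapiens), with a stated time of 30 min; a higher number here means a weaker inhibitor, a lower number a stronger inhibitor:

Compound 1, `CCOC(=O)c1cnc2scc(-c3cccc(C)c3)n12`: > 100000 nM — a limit of the assay, not a number.
Compound 2, `O=C(NCc1cnc2scc(-c3ccc(Br)cc3)n12)Nc1ccccc1`: 220 nM
Compound 3, `CCOC(=O)c1cnc2scc(-c3ccc(CC)cc3)n12`: 24000 nM

Compound 3 holds the highest of the two numbers that were actually read, so within this small set it is the weaker of the two; compound 2, which carries a different side chain and a different substituent on its outer ring, sits far lower, beyond the scatter. Compound 1 is known only as a limit of > 100000 nM in this assay, at which 1 of the 3 values shown sits, and can only be said to lie at the weak end.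

Compound 4, `CCOC(=O)c1cnc2scc(-c3ccc(OC)cc3)n12`, keeps the shared core and the ester of compound 3 and changes only the outer ring: methoxy in place of ethyl on an aromatic carbon. Among the measured compounds shown here, no pair of measured compounds shows this particular change, so the size of the step can only be guessed. Both groups are small and without charge, and the series of esters gives no sign of strong potency, so no step beyond the scatter is expected in either direction. Compound 4 is thus estimated at 30000 nM, between 8000 nM and 100000 nM, which means an expected step of a 1.3-fold higher number from compound 3 to compound 4 (0.10 log units; within the scatter).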

Compound 4, half-maximal inhibitory concentration: 56000 nM
For compound 4 the middle estimate is 1.9-fold (0.27 log units) below the measured one; the measured number falls inside the stated range.
By their numbers in this assay, from the lowest: compound 2; then compound 3; then compound 4. At a limit, above all of these: compound 1.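

In this assay, among the compounds shown here, the pair gives the first reading of a single change at this position, with the shared core and the ester held fixed: methoxy in place of ethyl on an aromatic carbon brings a 2.3-fold higher number from compound 3 to compound 4 (0.37 log units; beyond the scatter). The two groups have the same count of heavy atoms and neither carries a net charge, yet methoxy holds a hydrogen-bond acceptor that ethyl lacks, so the position does not treat these two groups alike, though the shift is small and leaves both esters far from the number of compound 2. Nothing measured here speaks to why the number moves in this direction.

From the compounds shown here alone, whether a longer chain, an amine or a carboxylic acid on this same aromatic carbon would carry the number further up or bring it down remains open. Also open, going by these compounds, is how the bromine and the side chain each contribute to the value of compound 2 at 220 nM, as that compound differs from the esters in more than one place.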